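Cytotoxicity of a cyclopropyl quinolone series on Vero cells

The compounds below may be only part of what the source reports. "The series", "measured", "known", "first", "only" and "open" are said of these compounds alone.

This account concerns four compounds sharing one core and differing only in the group on a saturated chain carbon bound to an amine nitrogen in a ring. In an ADME assay on Vero cells (Chlorocebus sabaeus) for cytotoxicity, read by MTT assay, with a stated time of 72 h (on this read-out higher numbers stand for lower toxicity in this test and lower numbers for higher toxicity in this test), compound 1 `COc1c(N2CCN(CC#N)C(C)C2)c(F)cc2c(=O)c(C(=O)O)cn(C3CC3)c12` gives 354 ug/mL, the second highest of the three numbers recorded. Compound 2 `COc1c(N2CCN(C/C(C)=N/NC(N)=O)C(C)C2)c(F)cc2c(=O)c(C(=O)O)cn(C3CC3)c12` gives 500 ug/mL, and the step of a 1.4-fold higher number from compound 1 to compound 2 (0.15 log units; within the scatter) lies within the scatter. Compound 3 `CO/N=C(\C)CCN1CCN(c2c(F)cc3c(=O)c(C(=O)O)cn(C4CC4)c3c2OC)CC1C` gives 157 ug/mL; the step of a 2.3-fold lower number from compound 1 to compound 3 (0.35 log units; beyond the scatter) is modest but beyond the scatter, as is a 3.2-fold lower number from compound 2 to compound 3 (0.50 log units; beyond the scatter).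

Compound 4 `CCO/N=C(\C)CCN1CCN(c2c(F)cc3c(=O)c(C(=O)O)cn(C4CC4)c3c2OC)CC1C` has not yet been measured. Relative to compound 1 the change is a group of 7 heavy atoms (5 carbon, 1 nitrogen, 1 oxygen; no ring) in place of a group of 2 heavy atoms (1 carbon, 1 nitrogen; no ring), on a saturated chain carbon bound to an amine nitrogen in a ring. The change leading to compound 4 is of the same kind as that leading to compound 3, and the step of a 2.3-fold lower number from compound 1 to compound 3 (0.35 log units; beyond the scatter) is therefore the one that bears most directly on it, whereas a 1.4-fold higher number from compound 1 to compound 2 (0.15 log units; within the scatter) shows a change of another kind leaving the number within the scatter. On this basis a modest step downward, beyond the scatter, is expected: a 2.5-fold lower number from compound 1 to compound 4 (0.40 log units; beyond the scatter). Compound 4 is thus estimated at 140 ug/mL, with a range of 70 ug/mL to 280 ug/mL.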

Compound 4, half-maximal cytotoxic concentration: 88.4 ug/mL
Beside the measured number, compound 4's estimate is 1.6-fold (0.20 log units) above it, within the range that was stated.
By their numbers in this assay, from the lowest: compounds 4 and 3 (each within the scatter of the next); then compounds 1 and 2 (each within the scatter of the next).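

In this assay, methyl in place of hydrogen on a saturated chain carbon bound to an oxygen on an unsaturated carbon gives a step that stays within the scatter (a 1.8-fold lower number from compound 3 to compound 4 (0.25 log units; within the scatter)), so compound 3 and compound 4 cannot be told apart, and this small change to the chain's end does not register as a real difference. What compound 4 adds is a second compound of this kind lying clearly beyond the scatter from both compounds with the higher numbers (a 4.0-fold lower number from compound 1 to compound 4 (0.60 log units; beyond the scatter); a 5.7-fold lower number from compound 2 to compound 4 (0.75 log units; beyond the scatter)), so the lower numbers among these four compounds are no longer carried by compound 3 alone, and neither compound 3 nor compound 4 goes against this. No measurement bears on why these numbers fall as they do.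

The compounds shown leave open whether a still longer group on that oxygen, such as propyl or benzyl, would move the number beyond the scatter from compound 3. They also leave open how a chain ending in an amine or a carboxylic acid would compare at this place on the shared core.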